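The source may hold more compounds than are shown below. What is called first, only, known or untested is meant among the compounds shown, and "the series" means these compounds.

Measured so far:
- compound 1, `O=C(O)c1ccc([N+](=O)[O-])c(COc2ccc(/C=C3\SC(=S)N(c4ccccc4)C3=O)cc2)c1`: in an assay on isolated protein for inhibition of Apoptosis regulator Bcl-2 (Homo sapiens), read by fluorescence polarization (on this read-out higher numbers stand for weaker inhibition and lower numbers for stronger inhibition), compound 1 gives 9000 nM.
- compound 2, `O=C(Nc1ccc(O)c(C(=O)O)c1)c1ccc(/C=C2\SC(=S)N(c3ccccc3)C2=O)cc1`: in this assay compound 2 reaches only a limit, > 10000 nM.
- compound 3, `Cc1cccc(N2C(=O)/C(=C/c3ccc(OCc4ccc(C(=O)O)cc4)cc3)SC2=S)c1`: in this assay compound 3 reaches only a limit, > 10000 nM.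

Compound 3 therefore stands at the edge of what this assay can report; its entry is a limit and not a number. It shares the limit of > 10000 nM in this assay, at which 2 of the 3 values shown sit, with compound 2, so two of the three entries are limits. Compound 1 alone returns a number, and that number is weak in its own right. Among the measured compounds shown here, no pair of measured compounds differs in a single place, so no measured step sizes any one change within this set.

Compound 4, `O=C(O)c1ccc(COc2ccc(/C=C3\SC(=S)N(c4c(F)cccc4F)C3=O)cc2)cc1`, differs from compound 3 by 2,6-difluorophenyl in place of 3-methylphenyl on an amide-type nitrogen in a ring. With compound 3 sitting at a limit, the measured values give no direction for this change; the step from compound 3 to compound 4 is expected to be a step that the limit leaves unreadable from compound 3 to compound 4, nothing beyond the scatter. On that basis compound 4 is expected to give 12000 nM in this assay, with a range from 4000 nM to 40000 nM, and a real chance that again only a limit is reported.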

Compound 4, inhibition constant: > 10000 nM
Compound 4 ended at the assay's limit; the forecaster's own chance of this, stated with the estimate: 55%; the middle value does not contradict the limit.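

In this assay compound 4 gives > 10000 nM as a limit and not a number. Compound 3 likewise gives > 10000 nM as a limit, so no step can be read between compound 3 and compound 4. Open remains whether 2,6-difluorophenyl and 3-methylphenyl on the amide-type nitrogen in a ring differ at all in Bcl-2 inhibition.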